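Benzoxazole thioether amides: liver microsome clearance notes

The compounds below may be only part of what the source reports. "The series", "measured", "known", "first", "only" and "open" are said of these compounds alone.

Measured so far:
Compound 1, `O=C(CCSc1nc2cc(Cl)ccc2o1)N1CCC1`: 3.7 mL/min/g
Compound 2, `COc1ccc2oc(SCCC(=O)N3CCCC3)nc2c1`: 6.1 mL/min/g
Compound 3, `Clc1ccc2oc(SCCCN3CCCC3)nc2c1`: 1.9 mL/min/g

In an ADME assay on microsomes from liver (Homo sapiens) for metabolic stability, read by LC-MS, using NADPH, with a stated time of 45 min, tested at 0.5 uM (a lower number here means slower removal, a higher number faster removal of the compound), compound 1 gives 3.7 mL/min/g. Its nearest neighbour on the numbers is compound 2, and its furthest is compound 3; the gap to each lies within the scatter, so the three numbers are not separated from one another by this assay. Going by the values given here, compound 2 differs from compound 1 in two places at once, and no single step links them; their two values alone say nothing beyond this.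

Among the compounds with values here, the one single-point step measured is a 1.9-fold lower number from compound 1 to compound 3 (0.29 log units; within the scatter), which does not separate the two compounds.

Compound 4, `CN1CCN(C(=O)CCSc2nc3cc(Cl)ccc3o2)CC1`, has not yet been measured. It differs from compound 1 by 4-methylpiperazin-1-yl in place of azetidin-1-yl on a carbonyl carbon. Within the data shown here, no measured step changes the group on the carbonyl carbon while keeping the carbonyl; the only step at this chain end, from compound 1 to compound 3, stays within the scatter. On that basis the step from compound 1 to compound 4 is expected to be a 1.1-fold lower number from compound 1 to compound 4 (0.02 log units; within the scatter), that is, no change beyond the scatter in either direction. Compound 4 is therefore estimated at 3.5 mL/min/g in this assay, with a range of 1.5 mL/min/g to 8 mL/min/g.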

Compound 4, intrinsic clearance in a liver preparation (reported as CLH), per the amount of preparation that the assay uses: 1.5 mL/min/g
Beside the measured number, compound 4's estimate is 2.3-fold (0.37 log units) above it; the range from low to high includes it.
By their numbers in this assay, from the lowest: compounds 4, 3, 1 and 2 (each within the scatter of the next, the first and the last beyond it).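

In this assay, going by these compounds alone, the swap of azetidin-1-yl for 4-methylpiperazin-1-yl on the carbonyl carbon gives a 2.5-fold lower number from compound 1 to compound 4 (0.39 log units; beyond the scatter), the first single-place change at this chain end to pass beyond the scatter, though only modestly. The earlier step at this end, a 1.9-fold lower number from compound 1 to compound 3 (0.29 log units; within the scatter), removed the carbonyl as well and did not separate its two compounds, whereas this one keeps the carbonyl and changes only the ring on it, showing that the number responds to the group at this position. No accompanying measurement bears on this step, so the data offer no account of it.

The step changes ring size, adds a second ring nitrogen and adds a methyl all at once, and the compounds shown cannot separate these contributions. Open questions are whether piperidin-1-yl, morpholin-4-yl or piperazin-1-yl with an unsubstituted ring nitrogen on the same carbonyl carbon would give a similar number, and whether the same swap would hold on the methoxy-bearing core of compound 2.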